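Swapping the Aryl Group on a Shared Core

The source may report more compounds than this note shows. Statements on the series, on what has been measured and on what is new or still open speak of the compounds shown alone.

Compound 1 `Cc1ccnc(NC(c2ccc(C(F)(F)F)cc2)c2ccc3cccnc3c2O)c1`: in an assay for inhibition of protein disulfide-isomerase (Homo sapiens), with a stated time of 1 h (a higher number here means a weaker inhibitor, a lower number a stronger inhibitor), compound 1 gives 26500 nM.
Compound 2 `Cc1ccnc(NC(c2cccc(F)c2)c2ccc3cccnc3c2O)c1`: in this assay compound 2 gives 350 nM.

Among the measured compounds shown here, compound 2 stands lowest of the two numbers, and the only measured step, a 76-fold lower number from compound 1 to compound 2 (1.88 log units; beyond the scatter), separates it from compound 1. Compound 3 `Cc1ccnc(NC(c2cc(C)ccc2C)c2ccc3cccnc3c2O)c1` is not yet measured; it differs from compound 2 by 2,5-dimethylphenyl in place of 3-fluorophenyl on a saturated chain carbon bound to an aromatic carbon and a nitrogen on an aromatic ring. That single step concerns a different aryl group, so it bears only loosely on this change. With no closer guide, a modest rise in this assay is expected, a 4.3-fold higher number from compound 2 to compound 3 (0.63 log units; beyond the scatter). For compound 3 the estimated value in this assay is 1500 nM, with a range from 300 nM to 8000 nM.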

Compound 3, half-maximal inhibitory concentration: > 40000 nM
Compound 3 ended at the assay's limit (the forecaster's own chance of this, stated with the estimate: 5%); middle value at least 26-fold (1.42 log units) from the limit.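

Compound 3 ends at a limit of this assay, not at a true number: the limit of > 40000 nM in this assay, at which 1 of the 3 values shown sits. This place on the saturated chain carbon proves unforgiving, since 2,5-dimethylphenyl in place of 3-fluorophenyl gives an at least 110-fold higher number from compound 2 to compound 3 (2.05 log units; beyond the scatter), and of the three aryl groups shown only 3-fluorophenyl keeps a low number. The other step, an at least 1.5-fold higher number from compound 1 to compound 3 (0.17 log units; that floor lies within the scatter), allows no order between those two weak compounds.

As far as these compounds go, whether a plain phenyl or a 3-chlorophenyl here would hold the low number of compound 2 stays open, as does what the single fluorine itself contributes.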